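Flipping One Chain Stereocentre in Compound 2

The source may report more compounds than this note shows. Statements on the series, on what has been measured and on what is new or still open speak of the compounds shown alone.

Compound 1 (`CC(C)[C@H](C[C@H]1OC(=O)NC1=O)c1ccc(-c2ccc3cccc(F)c3c2)[nH]c1=O`), compound 2 (`CC(C)[C@H](C[C@H]1SC(=O)NC1=O)c1ccc(-c2ccc3cccc(F)c3c2)[nH]c1=O`) and compound 3 (`CC(C)[C@H](C[C@@H]1OC(=O)NC1=O)c1ccc(-c2ccc3cccc(F)c3c2)[nH]c1=O`) share one core and have been tested in a physicochemical assay for solubility, in phosphate buffer, measured as kinetic solubility; on this read-out lower numbers stand for lower solubility and higher numbers for higher solubility. There, compound 1 gives 35400 nM, compound 2 gives 31200 nM and compound 3 gives 21100 nM. Compound 2 therefore stands level with the other two, since all three numbers lie within the scatter of one another.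

Compound 4 (`CC(C)[C@@H](C[C@H]1SC(=O)NC1=O)c1ccc(-c2ccc3cccc(F)c3c2)[nH]c1=O`) keeps everything in compound 2 except the configuration at one centre (the two compounds have the same atoms and bonds and differ only in configuration as drawn: 1 of 2 stereo elements differ; a stereocentre at a saturated chain carbon is drawn S in compound 2 and R in compound 4). Among the compounds with values here, the closest precedent is a configuration-only change at a saturated ring carbon rather than a chain carbon (a 1.7-fold lower number from compound 1 to compound 3 (0.22 log units; within the scatter)), and it stayed within the scatter. Exchanging the ring itself also stayed within the scatter (a 1.1-fold lower number from compound 1 to compound 2 (0.05 log units; within the scatter)). Within the data shown here, no measured step tests the chain carbon directly, so the guidance is indirect, and no step beyond the scatter is expected in this assay. The estimated change is small (a 1.1-fold lower number from compound 2 to compound 4 (0.05 log units; within the scatter)). For compound 4 the expected value is 28000 nM, with an estimated range from 12000 nM to 60000 nM.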

Compound 4, solubility: 23900 nM
Compound 4: the middle estimate sits 1.2-fold (0.07 log units) above what was measured; the measured number falls inside the stated range.
By their numbers in this assay, from the lowest: compounds 3, 4, 2 and 1 (each within the scatter of the next).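

Within the data shown here, the chain stereocentre now has a direct test, which the earlier compounds did not provide, and the comparison is a clean one: the fact that compounds 2 and 4 differ only in the configuration as drawn. In this assay, inverting this centre gives a 1.3-fold lower number from compound 2 to compound 4 (0.12 log units; within the scatter). Configuration has therefore now been changed at both a ring carbon and a chain carbon, and in these two pairs neither change moves the number beyond the scatter, the ring carbon case being a 1.7-fold lower number from compound 1 to compound 3 (0.22 log units; within the scatter).

The compounds shown leave open whether the chain carbon behaves the same way when it carries 2,4-dioxo-1,3-oxazolidin-5-yl, since this flip is seen only with 2,4-dioxo-1,3-thiazolidin-5-yl. They also leave open whether a carboxylic acid or an amine in place of that ring, on the same saturated chain carbon, would shift the number beyond the scatter.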